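Replacing the Arylamino Group of Compound 2

The compounds below may be only part of what the source reports. "The series", "measured", "known", "first", "only" and "open" are said of these compounds alone.

Compound 1 `Cc1ccc(Nc2nc(Cl)nc3c2ncn3Cc2ccc(C(=O)Nc3ccccc3N)cc2)cc1` and compound 2 `Nc1ccccc1NC(=O)c1ccc(Cn2cnc3c(Nc4cccc(Cl)c4)nc(Cl)nc32)cc1` share a core and differ only in the aryl group on the ring nitrogen. In a functional assay on NCI-H460 cells (Homo sapiens) for antiproliferative activity, read by CCK-8 assay, with a stated time of 72 h, tested at 8 uM (a higher number here means a stronger effect of the compound at the concentration tested, a lower number a weaker effect), compound 1 gives 82.5%, and compound 2 gives 67%. Among the compounds with values here, the single step between them, a number 15.5 percentage points lower from compound 1 to compound 2 (beyond the scatter), places compound 2 at the lower of the two numbers, with compound 1 the only neighbour.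

Compound 3 `CN1CCN(c2nc(Cl)nc3c2ncn3Cc2ccc(C(=O)Nc3ccccc3N)cc2)CC1` changes compound 2 at the same aromatic carbon: 4-methylpiperazin-1-yl in place of (3-chlorophenyl)amino on an aromatic carbon. Here the (3-chlorophenyl)amino group leaves and 4-methylpiperazin-1-yl enters, a six-membered non-aromatic ring with two hetero atoms and no hydrogen-bond donor. No measured step covers an exchange of this kind; the one step shown concerns two aryl groups and was modest. The direction is therefore open, and a step of about a number 17 percentage points lower from compound 2 to compound 3 (beyond the scatter) in this assay is expected, with wide uncertainty. Compound 3 is estimated at 50%, within 15% to 80%.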

Compound 3, a percentage reported as inhibition, at one concentration (the size of the read-out at that concentration, not a potency): 55.1%
Compound 3: middle estimate off by 5.1 percentage points, on the low side; measured number inside the range.
By their numbers in this assay, from the lowest: compound 3; then compound 2; then compound 1.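

In this assay, putting 4-methylpiperazin-1-yl on this aromatic carbon in place of (3-chlorophenyl)amino gives a number 11.9 percentage points lower from compound 2 to compound 3 (beyond the scatter) and the same group in place of (4-methylphenyl)amino gives a number 27.4 percentage points lower from compound 1 to compound 3 (beyond the scatter) in the same direction, so the exchange lowers the number from either arylamino compound. Compound 3, whose group has neither an aromatic ring nor a hydrogen-bond donor, still gives 55.1% at the tested concentration, so a non-aromatic ring at this position does not abolish the effect. No measurement at hand offers a reason for these steps.

The compounds shown do not separate the loss of the aromatic ring from the loss of the amino hydrogen. A cyclohexylamino group, which keeps that hydrogen on a non-aromatic ring, or a morpholin-4-yl group, would bear on this question.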